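The source may report more compounds than this note shows. Statements on the series, on what has been measured and on what is new or still open speak of the compounds shown alone.

Working notes on the series.

Three compounds carry measured numbers. Compound 1 `COc1cc2c(cc1N1C[C@@H](C)N[C@@H](C)C1)N(C(=O)c1ccc(-c3cccc(C)n3)c3ccccc13)CC2` gives 126 nM in an assay on isolated protein for binding affinity to 5-hydroxytryptamine receptor 1D (Homo sapiens) (a lower number here means a stronger inhibitor, a higher number a weaker inhibitor), and compound 2 `CCN1[C@H](C)CN(c2cc3c(cc2OC)CCN3C(=O)c2ccc(-c3cccc(C)n3)c3ccccc23)C[C@@H]1C` gives 126 nM. Compound 3 `COc1cc2c(cc1N1CCN(C)CC1)N(C(=O)Nc1cccc(Cl)c1Cl)CC2` gives 12.6 nM, the lowest of the three numbers; its nearest neighbour is compound 1, whose number is higher by an amount beyond the scatter, and compound 2 stands at the same distance. Compound 3 is therefore the strongest binder measured so far.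

Among the measured compounds shown here, the one measured step that changes only a single place is no change at the digits printed from compound 1 to compound 2 (within the scatter). It shows that adding an alkyl group on the amine nitrogen of the piperazine ring does not move the number.

Compound 4 `COc1cc2c(cc1N1C[C@@H](C)N(C)[C@@H](C)C1)N(C(=O)Nc1cccc(Cl)c1Cl)CC2` is not yet measured. It differs from compound 3 in one place: 3,4,5-trimethylpiperazin-1-yl in place of 4-methylpiperazin-1-yl on an aromatic carbon. For the measured compounds named here, no measured pair isolates this exact change; compounds 1 and 3 differ both in the piperazine substitution and in the acyl part, so their values cannot be read as a step for it. Going by the values given here, the only step in the piperazine region, from compound 1 to compound 2, lay within the scatter. The expected step from compound 3 to compound 4 is therefore small, a 1.2-fold higher number from compound 3 to compound 4 (0.08 log units; within the scatter), with no clear direction. Compound 4 is estimated at 15 nM, with a range from 5 nM to 45 nM.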

Compound 4, inhibition constant: 79.4 nM
Beside the measured number, compound 4's estimate is 5.3-fold (0.72 log units) below it; measured number above the stated range.
By their numbers in this assay, from the lowest: compound 3; then compounds 4, 1 and 2 (each within the scatter of the next).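

In this assay, replacing 4-methylpiperazin-1-yl with 3,4,5-trimethylpiperazin-1-yl gives a 6.3-fold higher number from compound 3 to compound 4 (0.80 log units; beyond the scatter), so this position on the aromatic carbon, ortho to a methoxy group, does respond to a change in the piperazine. The earlier step, no change at the digits printed from compound 1 to compound 2 (within the scatter), changed only the group on the ring nitrogen and gave no such signal, and it belongs to a different acyl part, so the new step shows that the piperazine region cannot be treated as indifferent to substitution across the series. No data at hand speak to the reason for the new step.

The compounds shown leave open whether the added methyl groups of 3,4,5-trimethylpiperazin-1-yl act together or one alone accounts for the step, and whether its defined stereocentres matter. They also leave open how an ethyl on the ring nitrogen, or a morpholine in place of the piperazine, would read on the core of compound 3.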